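The compounds below may be only part of what the source reports. "The series", "measured", "known", "first", "only" and "open" are said of these compounds alone.

Compound 1 `CCc1ccccc1N(CC(=O)NCc1ccccc1)S(=O)(=O)c1ccc(C)cc1`: 63.1 nM
Compound 2 `Cc1ccc(S(=O)(=O)N(CC(=O)NCc2ccc(Cl)cc2)c2cccnc2)cc1`: < 1000 nM
Compound 3 `Cc1ccc(S(=O)(=O)N(CC(=O)NCc2ccc(Cl)cc2)c2ccc(C)nc2)cc1`: < 1000 nM

In an assay on CHO cells for displacement of a labelled ligand from prostaglandin E2 receptor EP1 subtype (Homo sapiens) (on this read-out higher numbers stand for weaker inhibition and lower numbers for stronger inhibition), compound 1 gives 63.1 nM. For compound 2 the value < 1000 nM is a limit of the assay, not a number. For compound 3 the value < 1000 nM is likewise a limit of the assay and not a number. Going by the values given here, compound 3 therefore stands at the limit of < 1000 nM in this assay, at which 2 of the 3 values shown sit, and the only step leading to it, a step that the two limits leave unreadable from compound 2 to compound 3, gives no size. Compound 4 `CCn1nccc1N(CC(=O)NCc1ccc(Cl)cc1)S(=O)(=O)c1ccc(C)cc1` differs from compound 3 by 1-ethyl-1H-pyrazol-5-yl in place of 6-methylpyridin-3-yl on a sulfonamide nitrogen. Among the compounds with values here, no measured step covers such a ring exchange, so the expectation for compound 4 rests on where compound 3 stands and carries a wide range: compound 4 is estimated at 400 nM, between 40 nM and 4000 nM. The step that the limit leaves unreadable from compound 3 to compound 4 is thus expected to be small.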

Compound 4, inhibition constant: 158 nM
Beside the measured number, compound 4's estimate is 2.5-fold (0.40 log units) above it; the range from low to high includes it.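

Going by these compounds alone, no step to compound 4 can be read from compound 2 or compound 3, because both carry only a limit of the assay: the limit of < 1000 nM in this assay, at which 2 of the 4 values shown sit. From the compounds shown here alone, how much the ring exchange on the sulfonamide nitrogen changes binding stays open.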